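The source may report more compounds than this note shows. Statements on the series, on what has been measured and on what is new or still open speak of the compounds shown alone.

In a functional assay on HT-29 cells (Homo sapiens) for cytotoxicity, read by sulforhodamine B assay (a higher number here means that more compound is tolerated, a lower number that less compound is tolerated), compound 1 `CC1=CC[C@@H]([C@@](C)(O)CCCC(C)(C)NC(=S)NN)CC1` reads > 100000 nM, which is a limit and not a number. Compound 2 `CC1=CC[C@@H]([C@@](C)(O)CCCC(C)(C)NC(=S)N/N=C\c2ccc(N(C)C)cc2)CC1` reads > 100000 nM, also a limit. Going by the values given here, compound 3 `CC1=CC[C@@H]([C@@](C)(O)CCCC(C)(C)NC(=S)N/N=C\c2ccccc2[N+](=O)[O-])CC1` gives 44400 nM, the only actual number so far. Next is compound 4 `CC1=CC[C@@H]([C@@](C)(O)CCCC(C)(C)NC(=S)N/N=C\c2ccc(Cl)cc2)CC1`: 4-chlorophenyl in place of 2-nitrophenyl on a carbon with a double bond to nitrogen. Among the compounds with values here, one measured step bears on this place: an at least 2.2-fold lower number from compound 2 to compound 3 (0.35 log units; beyond the scatter). It starts from a limit, so it gives only a minimum size, and it involves a different pair of groups. It sets no direction for the new change, so no step beyond the scatter is expected in this assay. The estimated step is a 1.1-fold higher number from compound 3 to compound 4 (0.05 log units; within the scatter). For compound 4 the expected value is 50000 nM, with an estimated range of 20000 nM to 100000 nM.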

Compound 4, concentration lethal to 50% of the cells: 47300 nM
Compound 4: middle estimate off by 1.1-fold (0.02 log units), on the high side; the range from low to high includes it.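

In this assay, 4-chlorophenyl in place of 2-nitrophenyl on a carbon with a double bond to nitrogen leaves the reading unchanged within the scatter (a 1.1-fold higher number from compound 3 to compound 4 (0.03 log units; within the scatter)). Compound 4 also reads lower than both limit compounds, with chloro in place of dimethylamino on an aromatic carbon (an at least 2.1-fold lower number from compound 2 to compound 4 (0.32 log units; beyond the scatter)) and the larger aromatic group in place of one nitrogen atom (an at least 2.1-fold lower number from compound 1 to compound 4 (0.32 log units; beyond the scatter)). These two steps give only minimum sizes because each starts from a limit: the limit of > 100000 nM in this assay, at which 2 of the 4 values shown sit.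

Still open, on these data alone, is how a carboxylic acid or a primary amine on the aromatic ring would read. As far as these compounds go, a longer chain in place of the aromatic ring also remains untested in these data.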